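The source may hold more compounds than are shown below. What is called first, only, known or untested is meant among the compounds shown, and "the series" means these compounds.

Measured in a functional assay on HeLa cells (Homo sapiens) for cytotoxicity, read by MTT assay, with a stated time of 48 h; on this read-out higher numbers stand for weaker inhibition and lower numbers for stronger inhibition:
- compound 1 `Cc1ccc(C)c(/C=C/[C@](C)(O)CC[C@@H]2[C@@]3(C)CCCC(C)(C)[C@@H]3CC[C@@]2(C)O)c1`: 3380 nM
- compound 2 `CC1(C)CCC[C@]2(C)[C@@H](CC[C@@](C)(O)/C=C/c3ccc(Cl)nc3)[C@](C)(O)CC[C@@H]12`: 3680 nM
- compound 3 `CC1(C)CCC[C@]2(C)[C@@H](CC[C@@](C)(O)/C=C/c3ccc(Br)cc3)[C@](C)(O)CC[C@@H]12`: 45900 nM

Compound 3 gives the highest number of the three, clear of the other two, which show a 1.1-fold higher number from compound 1 to compound 2 (0.04 log units; within the scatter).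

Next is compound 4 `CC1(C)CCC[C@]2(C)[C@@H](CC[C@@](C)(O)/C=C/c3ccc(Oc4ccccc4)cc3)[C@](C)(O)CC[C@@H]12`, which differs from compound 3 by phenoxy in place of bromo on an aromatic carbon, para to a large group.

For the measured compounds named here, no measured step changes that substituent alone. The closest evidence comes from exchanges of the whole aryl group, a 14-fold higher number from compound 1 to compound 3 (1.13 log units; beyond the scatter) and a 12-fold higher number from compound 2 to compound 3 (1.10 log units; beyond the scatter), both large. These show that the aryl group can move the number strongly in this assay, but they do not show how phenoxy will act. Since compound 3 sits at the top of this small set at 45900 nM, a moderate move toward a lower number is expected, with wide uncertainty in either direction. The expected step is a 3.1-fold lower number from compound 3 to compound 4 (0.49 log units; beyond the scatter).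

For compound 4 the estimated value is 15000 nM.

The expected range for compound 4 runs from 3500 nM to 70000 nM.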

Compound 4, half-maximal inhibitory concentration: 3480 nM
Compound 4: middle estimate off by 4.3-fold (0.63 log units), on the high side, and the stated range ends above it.
By their numbers in this assay, from the lowest: compounds 1, 4 and 2 (each within the scatter of the next); then compound 3.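

On the aromatic carbon para to a large group, exchanging bromo for phenoxy alone gives a 13-fold lower number from compound 3 to compound 4 (1.12 log units; beyond the scatter) in this assay, so a single substituent at this position can carry a step as large as those seen on exchanging the whole aryl group. Compound 4 falls within the scatter of compounds 1 and 2, leaving compound 3 alone at the high end of the series. A para-substituted phenyl group therefore does not by itself bring the high number, as the group with the added six-membered aromatic ring sits with the 2,5-dimethylphenyl and 6-chloropyridin-3-yl compounds.

On these data alone, whether methoxy, an amine or a carboxylic acid at this carbon would follow bromo or phenoxy remains open. It is also open whether the oxygen link or the added ring carries the step, and nothing shown gives a reason for it.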